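Swapping the aryl group on the shared core

The compounds below may be only part of what the source reports. "The series", "measured", "known", "first", "only" and "open" are said of these compounds alone.

compound 1 `Cc1oc(-c2ccc(F)cc2)nc1CN1CCC(C(=O)NCCCN2C[C@H](C)C[C@H](C)C2)CC1`: 0.468 h
compound 2 `Cc1ccccc1-c1nc(CN2CCC(C(=O)NCCCN3CCCCC3)CC2)c(C)o1`: > 0.5 h, a limit
compound 3 `Cc1ccccc1-c1nc(CN2CCC(C(=O)N3CCN(CCN(C)C)CC3)CC2)c(C)o1`: > 0.5 h, a limit

Going by the values given here, in an ADME assay on microsomes from liver (Rattus norvegicus) for metabolic stability, read by LC-MS, using NADPH, at 37 degrees C (a higher number here means that the compound lasts longer, a lower number that the compound disappears faster), compound 1 gives 0.468 h, the only plain number among the three values shown. Compound 2 gives > 0.5 h, which is a limit of this assay. Compound 3 likewise gives > 0.5 h, also a limit. Both therefore sit at the limit of > 0.5 h in this assay, at which 2 of the 3 values shown sit. Among the compounds with values here, the one measured step, a step that the two limits leave unreadable from compound 2 to compound 3, changes the group on the carbonyl carbon and cannot be read in size.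

Compound 4 `COc1cccc(C)c1-c1nc(CN2CCC(C(=O)NCCCN3C[C@H](C)C[C@H](C)C3)CC2)c(C)o1` has not been measured. It differs from compound 1 by 2-methoxy-6-methylphenyl in place of 4-fluorophenyl on an aromatic carbon. No measured step touches this aryl group, and the one step shown lies elsewhere and is unreadable, so no step beyond the usual scatter is expected from compound 1 to compound 4, a 1.0-fold lower number from compound 1 to compound 4 (0.02 log units; within the scatter). Compound 4 is accordingly estimated at 0.45 h, with a range from 0.2 h to 1 h.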

Compound 4, half-life: 0.0767 h
Compound 4: the middle estimate sits 5.9-fold (0.77 log units) above what was measured; the whole stated range lies above it.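

In this assay the aryl group on the shared core proves not to be neutral: 2-methoxy-6-methylphenyl in place of 4-fluorophenyl gives a 6.1-fold lower number from compound 1 to compound 4 (0.79 log units; beyond the scatter) and so a compound that disappears faster. This is the first readable step beyond the scatter among the compounds shown, and it falls at this position on the aromatic carbon. Nothing measured here accounts for the step. The compounds shown leave open whether 2-methoxyphenyl alone would give such a step. They also leave open how a nitrile on this phenyl ring would fare.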